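This account rests on a few compounds, and the source may have more. Where it says the series, first, only, none or still open, it means among the compounds named here.

Of the compounds shown here, three share one core and have been tested in a functional assay on NCI-H460 cells (Homo sapiens) for antiproliferative activity, with a stated time of 72 h; a lower number here means a stronger inhibitor, a higher number a weaker inhibitor. Compound 1 `C=CC[C@H]1C[C@]2([C@@H](C)Cc3cccc(OC)c3)OCOC2=CC1=O` gives 10600 nM. Compound 2 `C=CC[C@H]1C[C@]2([C@@H](C)Cc3ccc(OC)c(C)c3)OCOC2=CC1=O` gives 630 nM, and compound 3 `C=CC[C@H]1C[C@]2([C@@H](C)Cc3cc(C)c(OC)cc3F)OCOC2=CC1=O` gives 650 nM. Compound 3 therefore stands second highest of the three numbers; its nearest neighbour is compound 2, and the two lie within the usual scatter of one another, while compound 1 sits well away from both.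

Within the data shown here, the only single-point step among the measured compounds is a 1.0-fold higher number from compound 2 to compound 3 (0.01 log units; within the scatter), a fluoro entering on an aromatic carbon, and it left the number essentially unchanged. Compound 1 and compound 2 differ in more than one place, so their gap cannot be tied to any one change.

Compound 4 `C=CC[C@H]1C[C@]2([C@@H](C)Cc3cc(O)c(OC)cc3F)OCOC2=CC1=O` differs from compound 3 by hydroxy in place of methyl on an aromatic carbon. Among the measured compounds shown here, no measured step shows what a hydroxy in place of a methyl does here, so the expectation rests on the general observation that the one single change seen so far moved the number little. The step of a 2.3-fold higher number from compound 3 to compound 4 (0.36 log units; beyond the scatter) is therefore expected to be modest, with a somewhat wider range allowed for the new group. The estimate for compound 4 in this assay is 1500 nM, expected to fall between 400 nM and 6000 nM.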

Compound 4, half-maximal inhibitory concentration: 33 nM
Beside the measured number, compound 4's estimate is 45-fold (1.66 log units) above it, outside the stated range (below it).
By their numbers in this assay, from the lowest: compound 4; then compounds 2 and 3 (each within the scatter of the next); then compound 1.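

Putting a hydroxy in place of the methyl on this aromatic carbon, ortho to a methoxy group and para to a fluoro group, gives a 20-fold lower number from compound 3 to compound 4 (1.29 log units; beyond the scatter) in this assay, so what sits at this position matters greatly to the antiproliferative number. Among these compounds, the only earlier single change, a 1.0-fold higher number from compound 2 to compound 3 (0.01 log units; within the scatter), left the number essentially where it was, so these two steps show that exchanging one heavy atom on the aromatic ring can do almost nothing or a great deal, depending on the group and its place. Nothing measured in this set explains why this step is so large.

The compounds shown leave open whether the gain belongs to the hydroxy itself or simply follows from the loss of the methyl, a question that a plain hydrogen or an amine on the same carbon would help to settle. They also leave open whether the same exchange would give a step of similar size on a ring without the fluoro group, such as the ring of compound 2.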